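A Dichlorohydroxyphenyl Sulfonamide Replaces the Pentafluorophenyl Group

The compounds below may be only part of what the source reports. "The series", "measured", "known", "first", "only" and "open" are said of these compounds alone.

Three compounds share one core and differ only in the aryl group on the sulfonyl sulfur. Compound 1 `COc1ccc(-c2cc(=O)c3c(OC)cc(OC)cc3n2S(=O)(=O)c2ccc(C#N)cc2)cc1` carries a 4-cyanophenyl group and in a functional assay on SUP-B15 cells (Homo sapiens) for antiproliferative activity, with a stated time of 72 h (a higher number here means that more compound is needed for the effect, a lower number that less compound is needed), compound 1 gives 7900 nM. Compound 2 `COc1ccc(-c2cc(=O)c3c(OC)cc(OC)cc3n2S(=O)(=O)c2cc(F)c(F)c(F)c2)cc1` carries a 3,4,5-trifluorophenyl group; for compound 2 the result is > 65500 nM, which is a limit of the assay and not a number. Compound 3 `COc1ccc(-c2cc(=O)c3c(OC)cc(OC)cc3n2S(=O)(=O)c2c(F)c(F)c(F)c(F)c2F)cc1` carries a 2,3,4,5,6-pentafluorophenyl group, and compound 3 gives 4100 nM, the lowest of the two numbers; its nearest neighbour is compound 1, and the step of a 1.9-fold lower number from compound 1 to compound 3 (0.28 log units; within the scatter) lies within the scatter. The step of an at least 15-fold lower number from compound 2 to compound 3 (1.20 log units; beyond the scatter) is large, and the step of an at least 8.2-fold higher number from compound 1 to compound 2 (0.91 log units; beyond the scatter) runs the other way.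

Compound 4 `COc1ccc(-c2cc(=O)c3c(OC)cc(OC)cc3n2S(=O)(=O)c2cc(Cl)cc(Cl)c2O)cc1` is the next variant: 3,5-dichloro-2-hydroxyphenyl in place of 2,3,4,5,6-pentafluorophenyl on a sulfonyl sulfur. Among the measured compounds shown here, none of the measured steps introduces a hydroxyl or a chlorine on this aryl group, so they give the direction of this step only loosely; they do show that the aryl group on the sulfonyl sulfur can move the number by a large amount in either direction. Compound 4 is therefore expected to land near compound 3 with wide uncertainty, at an estimated 7000 nM, between 1500 nM and 40000 nM, an expected step of a 1.7-fold higher number from compound 3 to compound 4 (0.23 log units; within the scatter).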

Compound 4, half-maximal effective concentration: > 37900 nM
Compound 4: no number, only a limit; the forecaster's own chance of this, stated with the estimate: 20%; middle value at least 5.4-fold (0.73 log units) from the limit.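

Compound 4 yields only a limit of the assay and not a number: the limit of > 37900 nM in this assay, at which 1 of the 4 values shown sits.

Measured against the two aryl groups that have numbers, the 3,5-dichloro-2-hydroxyphenyl group lies beyond the scatter in the unfavourable direction, with an at least 9.2-fold higher number from compound 3 to compound 4 (0.96 log units; beyond the scatter) and an at least 4.7-fold higher number from compound 1 to compound 4 (0.68 log units; beyond the scatter). This shows that a sulfonyl sulfur whose other neighbour is the aromatic nitrogen does not accept every substituted aryl group as it accepts 2,3,4,5,6-pentafluorophenyl or 4-cyanophenyl, and that a high number here is not confined to the fluorinated compound 2, since an aryl group with chlorine and a hydroxyl also ends at a limit. The step between compound 2 and compound 4 cannot be read, as both values are limits, so the two cannot be ordered.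

The compounds shown leave open whether the hydroxyl or the chlorines account for the higher number, as none of them carries one without the other. They also leave open how an amine or a carboxylic acid on this aryl group would behave in place of the hydroxyl.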